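The compounds below may be only part of what the source reports. "The series", "measured", "known", "first", "only" and "open" are said of these compounds alone.

Compound 1, `NC(=O)c1c(NC(=O)c2ccccc2Cl)sc2c1CCN(Cc1c(Cl)cccc1Cl)C2`, is the starting point. Among the compounds with values here, in a functional assay on HL-60 cells (Homo sapiens) for antiproliferative activity, with a stated time of 24 h (a higher number here means a weaker inhibitor, a lower number a stronger inhibitor), compound 1 gives 4850 nM, the lowest of the three numbers measured so far. Two close relatives differ from it only in the aromatic ring attached to the carbonyl carbon of the amide. Compound 2, `Cc1ccc(C(=O)Nc2sc3c(c2C(N)=O)CCN(Cc2c(Cl)cccc2Cl)C3)cc1`, carries a 4-methylphenyl there and gives 10000 nM. Compound 3, `NC(=O)c1c(NC(=O)c2ccccc2F)sc2c1CCN(Cc1c(Cl)cccc1Cl)C2`, carries a 2-fluorophenyl and gives 10300 nM. Both shifts are modest: a 2.1-fold higher number from compound 1 to compound 2 (0.31 log units; beyond the scatter) and a 2.1-fold higher number from compound 1 to compound 3 (0.33 log units; beyond the scatter), while a 1.0-fold higher number from compound 2 to compound 3 (0.01 log units; within the scatter).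

Compound 4, `CSc1ccccc1NC(=S)N1CCc2c(sc(NC(=O)c3ccccc3Cl)c2C(N)=O)C1`, keeps the 2-chlorophenyl amide of compound 1 and alters a different part of the molecule: a group of 11 heavy atoms (8 carbon, 1 nitrogen, 2 sulfur; one six-membered aromatic ring of carbon only) in place of a group of 9 heavy atoms (7 carbon, 2 chlorine; one six-membered aromatic ring of carbon only), on an amine nitrogen in a ring. Within the data shown here, none of the measured steps touches this position; all three concern only the amide aryl group, so they offer no direct guide to the size or direction of the step. The shared core and the amide are untouched, which argues for staying near compound 1, but nothing measured here shows what the new group does, so the uncertainty is wide. The expected outcome is a 1.0-fold higher number from compound 1 to compound 4 (0.01 log units; within the scatter). Compound 4 is estimated at 5000 nM, plausibly between 1200 nM and 20000 nM.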

Compound 4, half-maximal inhibitory concentration: 14600 nM
Compound 4: the middle estimate sits 2.9-fold (0.47 log units) below what was measured; the measured number falls inside the stated range.
By their numbers in this assay, from the lowest: compound 1; then compounds 2, 3 and 4 (each within the scatter of the next).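

Within the data shown here, on the amine nitrogen in the ring, the earlier compounds gave no reading, and here the first change at this position moves the result: in this assay, replacing the 2,6-dichlorobenzyl group with the new group gives a 3.0-fold higher number from compound 1 to compound 4 (0.48 log units; beyond the scatter) as a modest but real loss. The entering group differs in several ways at once, losing both chlorine atoms and bringing in nitrogen, sulfur, a double bond outside the aromatic ring and hydrogen-bond donor and acceptor atoms, yet the number stays within a modest step of compound 1. No measurement available here explains why the number moved.

Among these compounds, with so many features changed together, the single step cannot show which of them accounts for the shift, or whether the chlorine atoms of the 2,6-dichlorobenzyl group matter on their own. From the compounds shown here alone, a plain benzyl group or a simple methyl group on this nitrogen would help separate those features, and it remains open whether the step would be the same size alongside the 4-methylphenyl or 2-fluorophenyl amide.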